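This account rests on a few compounds, and the source may have more. Where it says the series, first, only, none or still open, it means among the compounds named here.

Measured so far:
compound 1, `Cc1ccccc1-c1nc(CN2CCC(C(=O)NCCN3C[C@H](C)C[C@H](C)C3)CC2)c(C)o1`: > 0.5 h
compound 2, `Cc1oc(-c2c(Cl)cccc2C(F)(F)F)nc1CN1CCC(C(=O)NCCCN2C[C@H](C)C[C@H](C)C2)CC1`: 0.03 h

Among the measured compounds shown here, in an ADME assay on microsomes from liver (Rattus norvegicus) for metabolic stability, read by LC-MS, using NADPH, at 37 degrees C (a higher number here means that the compound lasts longer, a lower number that the compound disappears faster), compound 2 gives 0.03 h, the only plain number in the set, so compound 2 is the reference point for this series. The value of compound 1 in this assay is a limit of the assay and not a number: the limit of > 0.5 h in this assay, at which 1 of the 2 values shown sits. For the measured compounds named here, compound 1 and compound 2 differ in more than one place, so no single step connects them. Compound 3, `Cc1cc(C)cc(-c2nc(CN3CCC(C(=O)NCCCN4C[C@H](C)C[C@H](C)C4)CC3)c(C)o2)c1`, is not yet measured. It differs from compound 2 in one place: 3,5-dimethylphenyl in place of 2-chloro-6-(trifluoromethyl)phenyl on an aromatic carbon. Going by the values given here, no step between measured compounds is known, so the size of this change in this assay cannot be read from a measured pair. The expected step from compound 2 to compound 3 in this assay is an increase beyond the usual scatter, a 6.7-fold higher number from compound 2 to compound 3 (0.82 log units; beyond the scatter). In this assay compound 3 is expected to give 0.2 h, with a range from 0.05 h to 0.6 h.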

Compound 3, half-life: < 0.5 h
Compound 3 was reported as a limit; the forecaster's own chance of this, stated with the estimate: 25%; the middle value does not contradict the limit.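

In this assay, among the compounds shown here, compound 3 gives < 0.5 h, a limit and not a number, so no step between compound 2 and compound 3 can be read. The compounds shown leave open whether 3,5-dimethylphenyl in place of 2-chloro-6-(trifluoromethyl)phenyl changes the half-life, and by how much.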